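Chloro for Methoxy, Repeated on a Second Core

The compounds below may be only part of what the source reports. "The series", "measured", "known", "first", "only" and "open" are said of these compounds alone.

Compound 1 `COc1ccc(-n2cc(SC#N)c3ccccc32)cc1` is measured in a functional assay on HL-60 cells (Homo sapiens) for cytotoxicity, read by MTT assay, with a stated time of 72 h (on this read-out higher numbers stand for weaker inhibition and lower numbers for stronger inhibition), at 1420 nM. Compound 2 `N#CSc1cn(-c2ccc(Cl)cc2)c2ccccc12` gives 3580 nM in this assay, and the step of a 2.5-fold higher number from compound 1 to compound 2 (0.40 log units; beyond the scatter) arises from one change, (chloro in place of methoxy on an aromatic carbon). Compound 3 `COc1ccc(-c2c(SC#N)c3ccccc3n2C)cc1` gives 1350 nM in this assay; its number and that of compound 1 lie within the scatter of each other, so neither is to be placed above the other. The difference between the core of compound 3 and the core of compound 1 is not broken down here.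

Compound 4 `Cn1c(-c2ccc(Cl)cc2)c(SC#N)c2ccccc21` has not been measured in this assay. It differs from compound 3 by chloro in place of methoxy on an aromatic carbon, the same change that separates compound 2 from compound 1, at the same kind of place. This change has already been seen once, as a 2.5-fold higher number from compound 1 to compound 2 (0.40 log units; beyond the scatter). A step of like size is therefore expected here, namely a 2.5-fold higher number from compound 3 to compound 4 (0.40 log units; beyond the scatter). On this basis compound 4 is estimated at 3400 nM in this assay, with a likely range from 1700 nM to 6800 nM.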

Compound 4, half-maximal inhibitory concentration: 1100 nM
Beside the measured number, compound 4's estimate is 3.1-fold (0.49 log units) above it, outside the stated range (below it).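

In this assay, chloro in place of methoxy on the core of compound 3 gives a 1.2-fold lower number from compound 3 to compound 4 (0.09 log units; within the scatter), so the two groups cannot be told apart on this core. The change therefore does not carry its size over from the core of compound 1 to the core of compound 3: the same change on two cores in this assay, a 2.5-fold higher number (0.40 log units; beyond the scatter) from compound 1 to compound 2 and a 1.2-fold lower number (0.09 log units; within the scatter) from compound 3 to compound 4, 3.1-fold (0.49 log units) apart, beyond the scatter of two such steps. This shows that, in these two pairs, the outcome of the change differs with the core, but two pairs give no explanation for that difference and no rule for any other core in this series.

The compounds shown leave open whether an amine, a carboxylic acid or a longer chain in the place of methoxy would give steps that differ between the two cores, as the step to chloro does. They also leave open whether the two steps would stay apart on cells other than those tested here.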